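This account rests on a few compounds, and the source may have more. Where it says the series, first, only, none or still open, it means among the compounds named here.

Measured compounds in an ADME assay on MRC5 cells (Homo sapiens) for cytotoxicity, read by MTT assay, with a stated time of 24 h; a lower number here means a stronger inhibitor, a higher number a weaker inhibitor:
- compound 1, `CCOC(=O)c1c(C)[nH]c(=O)c(C#N)c1-c1ccccc1`: 220000 nM
- compound 2, `CCOC(=O)c1c(C)[nH]c(=O)c(C#N)c1-c1ccc(C)cc1`: 438000 nM
- compound 3, `CCOC(=O)c1c(C)[nH]c(=O)c(C#N)c1-c1ccc(OC)cc1`: 192000 nM

Compound 3 gives the lowest of the three numbers in this assay, but compound 1 sits within the scatter of it, so the two cannot be ordered; only compound 2 stands apart, as a 2.3-fold lower number from compound 2 to compound 3 (0.36 log units; beyond the scatter) shows.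

Compound 4, `CCOC(=O)c1c(C)[nH]c(=O)c(C#N)c1-c1ccc([N+](=O)[O-])cc1`, is not yet measured. It differs from compound 3 by nitro in place of methoxy on an aromatic carbon.

Among the measured compounds shown here, no measured step bears on a nitro group. The steps that touch the same position are a 1.1-fold lower number from compound 1 to compound 3 (0.06 log units; within the scatter) and a 2.0-fold higher number from compound 1 to compound 2 (0.30 log units; within the scatter), both within the scatter, and a 2.3-fold lower number from compound 2 to compound 3 (0.36 log units; beyond the scatter), a modest step. All three substitutions at this position thus move the number little, and no reason exists in these data to expect a larger step for compound 4; the expected step of a 1.1-fold higher number from compound 3 to compound 4 (0.04 log units; within the scatter) is therefore none beyond the scatter.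

Compound 4 is expected to give about 210000 nM in this assay, within a range from 90000 nM to 480000 nM.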

Compound 4, half-maximal inhibitory concentration: 2230000 nM
The estimate for compound 4 lay 11-fold (1.03 log units) below the measured number; measured number above the stated range.
By their numbers in this assay, from the lowest: compounds 3, 1 and 2 (each within the scatter of the next, the first and the last beyond it); then compound 4.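

Notes on the series: in this assay this position proves far more sensitive than the steps among compound 1, compound 2 and compound 3 suggested, as those were no more than modest, whereas nitro gives a 12-fold higher number from compound 3 to compound 4 (1.07 log units; beyond the scatter) and a 10-fold higher number from compound 1 to compound 4 (1.01 log units; beyond the scatter) and, from the highest of the earlier numbers, still gives a 5.1-fold higher number from compound 2 to compound 4 (0.71 log units; beyond the scatter). Compound 4 is therefore the weakest inhibitor of the four, with its steps to all three others beyond the scatter. Nothing available explains why nitro departs from hydrogen, methyl and methoxy in this way.

Going by these compounds, whether this large shift is peculiar to nitro remains open, since an amine or a carboxylic acid at the same place could show either a similar step or none. The compounds shown also leave open whether nitro would have the same effect on another carbon of the ring.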